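A few compounds are considered here, and "the series" means these few. Any claim that something is new, unique, unknown or untested is made for them only; others in the source may bear on it.

Measured so far in a functional assay on MDA-MB-231 cells (Homo sapiens) for cytotoxicity, read by MTT assay, with a stated time of 38 h; a lower number here means a stronger inhibitor, a higher number a weaker inhibitor:
- compound 1 (`COc1cc(OC)c2c(=O)c(OCC(=O)N/N=C/c3sccc3C)c(-c3cc(OC)c(OC)c(OC)c3)oc2c1`) gives 4470 nM
- compound 2 (`COc1cc(OC)c2c(=O)c(OCCCCN3CCN(C)CC3)c(-c3cc(OC)c(OC)c(OC)c3)oc2c1`) gives 3870 nM

Compound 2 stands level with compound 1. Among the compounds with values here, the only measured step (a 1.2-fold lower number from compound 1 to compound 2 (0.06 log units; within the scatter)) lies within the scatter, so the two cannot be ranked.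

Compound 3 (`COc1cc(OC)c2c(=O)c(OCC(=O)N/N=C/c3ccccn3)c(-c3cc(OC)c(OC)c(OC)c3)oc2c1`) has no value yet. The structural change from compound 2 (a group of 11 heavy atoms (7 carbon, 3 nitrogen, 1 oxygen; one six-membered aromatic ring with 1 hetero atom) in place of a group of 10 heavy atoms (8 carbon, 2 nitrogen; one six-membered non-aromatic ring with 2 hetero atoms), on a saturated chain carbon bound to an oxygen on an aromatic ring) falls at the same place as the measured step, on a saturated chain carbon bound to an oxygen on an aromatic ring. One step is thin evidence, and this exact exchange has not been measured. Within the data shown here, still, the only exchange measured at this place, the one leading to compound 2 (a 1.2-fold lower number from compound 1 to compound 2 (0.06 log units; within the scatter)), stayed within the scatter. No shift beyond the scatter is therefore expected in this assay, and the estimated step (a 1.1-fold higher number from compound 2 to compound 3 (0.04 log units; within the scatter)) reflects that. For compound 3 the expected value is 4200 nM with an estimated range of 1600 nM to 11000 nM.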

Compound 3, half-maximal inhibitory concentration: 9890 nM
Beside the measured number, compound 3's estimate is 2.4-fold (0.37 log units) below it, and the stated range covers the measured number.
By their numbers in this assay, from the lowest: compounds 2 and 1 (each within the scatter of the next); then compound 3.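

Pyridin-2-yl in place of 3-methylthiophen-2-yl on a carbon with a double bond to nitrogen gives, in this assay, a 2.2-fold higher number from compound 1 to compound 3 (0.34 log units; beyond the scatter), so the aromatic ring at this end of the side chain affects the number, which compound 1 and compound 2 alone could not show. Within the data shown here, on a saturated chain carbon bound to an oxygen on an aromatic ring, a 2.6-fold higher number from compound 2 to compound 3 (0.41 log units; beyond the scatter), is also beyond the scatter, so exchanges at this place are not all silent, unlike the one earlier step there. No measurement at hand gives a reason for either step.

Open, on these data alone, is whether a plain phenyl or a 4-methoxyphenyl on that carbon would follow compound 1 or compound 3. Also open, as far as these compounds go, is whether a morpholine in place of the methylpiperazine, or a longer chain carrying it, would stay level with compound 2.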